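Does a longer sulfur chain keep toxicity at the limit?

This account rests on a few compounds, and the source may have more. Where it says the series, first, only, none or still open, it means among the compounds named here.

- Compound 1 `CC(c1cc(O)nc(SC2CCCCC2)n1)c1c(Cl)cccc1Cl` gives > 200000 nM (a limit)
- Compound 2 `CSc1nc(O)cc(C(C)c2c(F)cccc2F)n1` gives 20800 nM
- Compound 3 `CSc1nc(O)c(C)c(C(C)c2c(F)cccc2F)n1` gives > 200000 nM (a limit)
- Compound 4 `Cc1c(O)nc(SCC(C)C)nc1C(C)c1c(F)cccc1F` has not yet been measured

In a functional assay on MT4 cells (Homo sapiens) for cytotoxicity (on this read-out higher numbers stand for lower toxicity in this test and lower numbers for higher toxicity in this test), compound 3 gives no exact number, and it stands at the limit of > 200000 nM in this assay, at which 2 of the 3 values shown sit. The next change, leading to compound 4, is isopropyl in place of hydrogen on a saturated chain carbon bound to a sulfur, which turns methylsulfanyl into isobutylsulfanyl.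

For the measured compounds named here, no measured step changes this group on the sulfur, so none bears on it directly. The nearest measured change is an at least 9.6-fold higher number from compound 2 to compound 3 (0.98 log units; beyond the scatter), made by methyl in place of hydrogen on an aromatic carbon, and compound 4 keeps that methyl. With that methyl retained, the number should stay close to the limit, although a measurable value is possible. The expected change is an at least 1.3-fold lower number from compound 3 to compound 4 (0.12 log units; that floor lies within the scatter), which means no shift beyond the scatter is expected in this assay. For compound 4 the estimated value is 150000 nM, with an expected range from 50000 nM to 200000 nM.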

Compound 4, half-maximal cytotoxic concentration: > 200000 nM
Compound 4 was reported as a limit; the forecaster's own chance of this, stated with the estimate: 55%; middle value at least 1.3-fold (0.12 log units) from the limit.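

No size can be read for the step between compound 3 and compound 4, since both are reported only as limits in this assay: the limit of > 200000 nM in this assay, at which 3 of the 4 values shown sit.

The compounds shown leave open whether isobutylsulfanyl in place of methylsulfanyl changes toxicity in this test at all.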